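The source may hold more compounds than are shown below. What is called first, only, known or untested is meant among the compounds shown, and "the series" means these compounds.

Measured compounds in a functional assay on NCI-H460 cells (Homo sapiens) for cytotoxicity, read by MTT assay, with a stated time of 72 h; on this read-out higher numbers stand for weaker inhibition and lower numbers for stronger inhibition:
compound 1 `COc1cc2c(Oc3ccc(NC(=O)c4cc(-c5ccccc5)ccn4)cc3F)ccnc2cc1OCCCN1CCN(C)CC1` gives 91 nM
compound 2 `COc1cc2c(Oc3ccc(NC(=O)c4cc(-c5ccccc5C)ccn4)cc3F)ccnc2cc1OCCCN1CCN(C)CC1` gives 150 nM
compound 3 `COc1cc2c(Oc3ccc(NC(=O)c4cc(-c5ccc(F)cc5)ccn4)cc3F)ccnc2cc1OCCCN1CCN(C)CC1` gives 430 nM

Compound 3 stands at the highest number of the three in this assay, the step of a 4.7-fold higher number from compound 1 to compound 3 (0.67 log units; beyond the scatter) being the largest one recorded and a 2.9-fold higher number from compound 2 to compound 3 (0.46 log units; beyond the scatter) the nearer one, both beyond the scatter. The step of a 1.6-fold higher number from compound 1 to compound 2 (0.22 log units; within the scatter) stays within the scatter.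

Compound 4 `COc1ccc(-c2ccnc(C(=O)Nc3ccc(Oc4ccnc5cc(OCCCN6CCN(C)CC6)c(OC)cc45)c(F)c3)c2)cc1` is not yet measured. The change from compound 3 is methoxy in place of fluoro on an aromatic carbon.

Within the data shown here, no measured step swaps one substituent for another at this same position of the phenyl ring; the closest precedents are a 4.7-fold higher number from compound 1 to compound 3 (0.67 log units; beyond the scatter), where the fluoro enters, and a 2.9-fold higher number from compound 2 to compound 3 (0.46 log units; beyond the scatter), where the whole 4-fluorophenyl replaces a 2-methylphenyl. Both show that the phenyl substitution pattern matters by a modest amount, but neither tells the direction for a methoxy. The expectation for compound 4 is therefore a step of a 1.2-fold lower number from compound 3 to compound 4 (0.09 log units; within the scatter), with wide uncertainty on either side.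

Compound 4 is estimated at 350 nM in this assay, in a range from 120 nM to 1000 nM.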

Compound 4, half-maximal inhibitory concentration: 370 nM
The estimate for compound 4 lay 1.1-fold (0.02 log units) below the measured number; low and high end bracket the measured number.
By their numbers in this assay, from the lowest: compounds 1 and 2 (each within the scatter of the next); then compounds 4 and 3 (each within the scatter of the next).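

In this assay, methoxy in place of fluoro on the phenyl ring, para to a large group, gives a 1.2-fold lower number from compound 3 to compound 4 (0.07 log units; within the scatter), so the two substituents cannot be told apart here, even though methoxy brings one more heavy atom and a hydrogen-bond acceptor. The rise seen with fluoro is therefore not unique to fluoro, since the step to the 4-methoxyphenyl from the unsubstituted phenyl is a 4.1-fold higher number from compound 1 to compound 4 (0.61 log units; beyond the scatter), beyond the scatter like a 4.7-fold higher number from compound 1 to compound 3 (0.67 log units; beyond the scatter), and in these two compounds a group at this place goes with a higher number than hydrogen. The 2-methylphenyl group does not follow that pattern, with a 1.6-fold higher number from compound 1 to compound 2 (0.22 log units; within the scatter), and the 4-methoxyphenyl also separates from it, at a 2.5-fold higher number from compound 2 to compound 4 (0.39 log units; beyond the scatter).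

Nothing available accounts for these numbers. As far as these compounds go, two groups at this place are too few to show whether the higher number holds generally, so it remains open whether an amine, a carboxylic acid or a longer alkoxy chain there would match fluoro and methoxy or return towards the unsubstituted phenyl.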